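Cyclopropyl(formyl)amino replacing ethyl(methyl)amino on the shared core

The source may report more compounds than this note shows. Statements on the series, on what has been measured and on what is new or still open speak of the compounds shown alone.

Two compounds of the series have numbers. Compound 1 `Nc1ncnc2c1ncn2CC1CC1` carries an amino group on the shared core; in a functional assay on the whole organism for antagonist activity, with Rattus norvegicus as the target (on this read-out higher numbers stand for an effect only at larger amounts of compound and lower numbers for an effect already at smaller amounts), compound 1 gives 20 mg/kg. Compound 2 `CCN(C)c1ncnc2c1ncn2CC1CC1` carries ethyl(methyl)amino at the same place, and in this assay compound 2 gives 12.5 mg/kg. For the measured compounds named here, on these two numbers compound 2 stands alongside compound 1, the only step so far being a 1.6-fold lower number from compound 1 to compound 2 (0.20 log units; within the scatter), which does not separate the two.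

Compound 3 `O=CN(c1ncnc2c1ncn2CC1CC1)C1CC1` is not yet measured. It differs from compound 2 in one place: cyclopropyl(formyl)amino in place of ethyl(methyl)amino on an aromatic carbon. Going by the values given here, the only measured step that bears on a change at this position is the one from compound 1 to compound 2, and it stayed within the scatter. Nothing in the series shows what a formyl group or a cyclopropyl ring on this nitrogen does. The expectation for this assay is therefore a step of a 1.2-fold higher number from compound 2 to compound 3 (0.08 log units; within the scatter), that is, no move beyond the scatter, with a wide range to allow for the larger change in the group. Compound 3 is estimated at 15 mg/kg, between 6 mg/kg and 40 mg/kg.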

Compound 3, dose for half-maximal effect: 8 mg/kg
Estimate against measurement, compound 3: 1.9-fold (0.27 log units) above; the measured number falls inside the stated range.
By their numbers in this assay, from the lowest: compounds 3, 2 and 1 (each within the scatter of the next, the first and the last beyond it).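

In this assay, cyclopropyl(formyl)amino in place of ethyl(methyl)amino on this aromatic carbon gives a 1.6-fold lower number from compound 2 to compound 3 (0.19 log units; within the scatter), so compound 2 and compound 3 are not separated, and a group with a formyl on the nitrogen and a three-membered ring is accommodated at this position without a move beyond the scatter. Measured against the plain amino group, the same group gives a 2.5-fold lower number from compound 1 to compound 3 (0.40 log units; beyond the scatter), a modest step but the first at this position to lie beyond the scatter, whereas ethyl(methyl)amino in compound 2 stayed within the scatter of compound 1. No evidence is at hand that accounts for either step.

From the compounds shown here alone, the formyl and the cyclopropyl ring enter together, so the share of each in the step from compound 1 stays open, and cyclopropylamino without the formyl, or an acetyl in place of the formyl, would be needed to part them. Also open, going by these compounds, is whether the lower number holds for larger groups on this nitrogen, such as a cyclohexyl ring or a longer acyl chain.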